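Amine variation on the shared core: notes toward compound 3

The source may hold more compounds than are shown below. What is called first, only, known or untested is meant among the compounds shown, and "the series" means these compounds.

Measured so far:
compound 1 `CNC1CCN(c2ccc3[nH]nc(-c4cnn(C)c4)c3c2)C1` — 432000 nM
compound 2 `Cn1cc(-c2n[nH]c3ccc(N[C@H]4CCNC4)cc23)cn1` — 239000 nM

In an assay on isolated protein for inhibition of tyrosine-protein kinase receptor UFO (Homo sapiens), with a stated time of 1.5 h (on this read-out higher numbers stand for weaker inhibition and lower numbers for stronger inhibition), compound 1 gives 432000 nM and compound 2 gives 239000 nM. Compound 2 carries the lower of the two numbers, yet a 1.8-fold lower number from compound 1 to compound 2 (0.26 log units; within the scatter) lies within the scatter, so the two stand level. Compound 3 `CN1CCC(CNc2ccc3[nH]nc(-c4cnn(C)c4)c3c2)CC1` follows from compound 2 by (1-methylpiperidin-4-yl)methyl in place of pyrrolidin-3-yl on a nitrogen on an aromatic ring. Among the measured compounds shown here, the only measured step bearing on this, a 1.8-fold lower number from compound 1 to compound 2 (0.26 log units; within the scatter), also reworks the amine and stays within the scatter; nothing measured touches the shared core. The step expected in this assay is a 1.0-fold higher number from compound 2 to compound 3 (0.02 log units; within the scatter), nothing beyond the scatter. Compound 3 is estimated at 250000 nM, range 80000 nM to 800000 nM.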

Compound 3, half-maximal inhibitory concentration: 1850000 nM
Compound 3: middle estimate off by 7.4-fold (0.87 log units), on the low side, and the stated range ends below it.
By their numbers in this assay, from the lowest: compounds 2 and 1 (each within the scatter of the next); then compound 3.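

In this assay, among the compounds shown here, the amine on a nitrogen on an aromatic ring now matters: (1-methylpiperidin-4-yl)methyl in place of pyrrolidin-3-yl gives a 7.7-fold higher number from compound 2 to compound 3 (0.89 log units; beyond the scatter), the first step beyond the scatter. The change replaces a five-membered non-aromatic ring with a six-membered one and also removes the defined stereocentre, so no single feature can be singled out. Nothing available explains the rise. As far as these compounds go, it remains open which part of the change carries the step, and whether a piperidin-4-yl group on the same nitrogen stays level with compound 2.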